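The source may hold more compounds than are shown below. What is called first, only, known or untested is meant among the compounds shown, and "the series" means these compounds.

In a functional assay on FaDu cells (Homo sapiens) for cytotoxicity, read by MTT assay, with a stated time of 72 h (on this read-out higher numbers stand for lower toxicity in this test and lower numbers for higher toxicity in this test), compound 1 `COc1ncc(NC(=O)C(=O)c2cn(C(C)C)c3ccccc23)cn1` gives 171 nM. Compound 2 `COCCn1cc(C(=O)C(=O)Nc2ccncc2)c2ccccc21` gives only a limit of the assay, > 10000 nM, and not a number. Compound 3 `COCCn1cc(C(=O)C(=O)Nc2cnc(OC)nc2)c2ccccc21` differs from compound 2 in one place: 2-methoxypyrimidin-5-yl in place of pyridin-4-yl on an amide-type nitrogen, with 2-methoxypyrimidin-5-yl in place of pyridin-4-yl on an amide-type nitrogen. Among the compounds with values here, no step between measured compounds is available. The expectation rests on compound 1, which also carries 2-methoxypyrimidin-5-yl and gives 171 nM. A large move towards lower numbers in this assay is therefore expected, estimated as an at least 16-fold lower number from compound 2 to compound 3 (1.22 log units; beyond the scatter). Compound 3 is expected at about 600 nM, within an estimated range of 120 nM to 3500 nM.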

Compound 3, concentration lethal to 50% of the cells: 55 nM
Estimate against measurement, compound 3: 11-fold (1.04 log units) above; measured number below the stated range.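

In this assay, the group on the amide-type nitrogen proves decisive for the 2-methoxyethyl compounds: 2-methoxypyrimidin-5-yl in place of pyridin-4-yl gives an at least 180-fold lower number from compound 2 to compound 3 (2.25 log units; beyond the scatter). Compound 2 stands at a limit of the assay and not at a number, so this step is only a bound: the limit of > 10000 nM in this assay, at which 1 of the 3 values shown sits. On the aromatic nitrogen, 2-methoxyethyl in place of isopropyl gives a modest step, a 3.1-fold lower number from compound 1 to compound 3 (0.49 log units; beyond the scatter).

On these data alone, it remains open whether an amine or a hydroxyl in place of the methoxy on the pyrimidine would keep these low numbers. As far as these compounds go, a longer chain on the aromatic nitrogen is equally open.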